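A Ring Swap at the Chain End of Compound 3

The source may hold more compounds than are shown below. What is called first, only, known or untested is meant among the compounds shown, and "the series" means these compounds.

Compound 3 `Cc1cc(OCCCCCCC[N+]2(C)CCCC2)cc(-n2cc(C(=O)Nc3cc(F)cc(F)c3)c(=O)c3ccc(N(C)C)nc32)c1` stands at the top of the two numbers available in an assay on LX2 cells for inhibition of COL1A1 promoter (Homo sapiens), read by a luciferase reporter, with a stated time of 24 h, tested at 50 uM; a lower number here means a weaker effect, a higher number a stronger effect of the compound at the concentration tested: compound 3 gives 35.4%. Compound 1 `Cc1cc(OCCCCCCC[N+]23CCN(CC2)CC3)cc(-n2cc(C(=O)Nc3cc(F)cc(F)c3)c(=O)c3ccc(N(C)C)nc32)c1` gives 5.52%, and compound 2 `CN(C)c1ccc2c(=O)c(C(=O)Nc3cc(F)cc(F)c3)cn(-c3ccc(OCCCCCCC[N+]4(C)CCCC4)cc3F)c2n1` is reported as "not active" (no number reported), with no number attached. Going by the values given here, the only step between measured compounds that changes one place, a number 29.9 percentage points higher from compound 1 to compound 3 (beyond the scatter), exchanged a group of 8 heavy atoms for a group of 6 heavy atoms at the same chain position, a modest gain beyond the scatter.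

Compound 4 `Cc1cc(OCCCCCCC[n+]2ccccc2)cc(-n2cc(C(=O)Nc3cc(F)cc(F)c3)c(=O)c3ccc(N(C)C)nc32)c1` differs from compound 3 in that same place: a group of 6 heavy atoms (5 carbon, 1 nitrogen; one six-membered aromatic ring with 1 hetero atom) in place of a group of 6 heavy atoms (5 carbon, 1 nitrogen; one five-membered non-aromatic ring with 1 hetero atom), on a saturated chain carbon, seven bonds along the chain from an oxygen on an aromatic ring. Among the compounds with values here, no measured step exchanges one group of 6 heavy atoms for another at this position. The step of a number 29.9 percentage points higher from compound 1 to compound 3 (beyond the scatter) shows that the group at the end of the chain can move the read-out modestly, but it does not say in which direction a group of the same atom count and a different ring would move it. The expectation is therefore a small step with wide uncertainty. For compound 4 the estimate in this assay is 27%, with a range from 5% to 48%. This corresponds to an expected step of a number 8.4 percentage points lower from compound 3 to compound 4 (within the scatter), which is expected to stay within the scatter.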

Compound 4, a percentage reported as inhibition, at one concentration (the size of the read-out at that concentration, not a potency): 61%
Compound 4: middle estimate off by 34 percentage points, on the low side, outside the stated range (above it).
By their numbers in this assay, from the lowest: compound 1; then compound 3; then compound 4.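

Replacing the saturated five-membered ring with a six-membered aromatic ring leaves the count of 6 heavy atoms and the net charge of +1 unchanged, yet this assay shows a number 25.6 percentage points higher from compound 3 to compound 4 (beyond the scatter) at this chain end. The read-out here therefore depends on the kind of ring, not only on how many atoms the group contains, and the widest step at this place is now a number 55.5 percentage points higher from compound 1 to compound 4 (beyond the scatter) among the three groups with numbers. The data at hand offer no measured explanation for why the aromatic ring gives the higher number.

The compounds shown leave open whether other aromatic groups at the chain end, such as an imidazolium or the aromatic ring of compound 4 carrying a methyl group, would give a similar read-out. They also leave open whether the advantage of this ring would hold on a shorter or longer chain, and how it would compare across a range of concentrations, as each number here describes a single concentration and is not a potency.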